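The source may report more compounds than this note shows. Statements on the series, on what has been measured and on what is new or still open speak of the compounds shown alone.

Series notes. Three compounds of the shared core have numbers in a functional assay on K562 cells (Homo sapiens) for inhibition, read by trypan blue exclusion, with a stated time of 72 h; on this read-out higher numbers stand for weaker inhibition and lower numbers for stronger inhibition. Compound 1 `Cn1c(=O)c(S(=O)(=O)c2ccc(Cl)cc2Cl)cc2cnc(Nc3ccc4[nH]ccc4c3)nc21` gives 1000 nM in this assay. Compound 2 `O=c1c(S(=O)(=O)c2ccc(F)cc2F)cc2cnc(Nc3ccc4[nH]ccc4c3)nc2n1C1CCCC1` gives 5000 nM. Compound 3 `Cn1c(=O)c(S(=O)(=O)c2ccc(OC(=O)CCCCC3SCC4NC(=O)NC43)cc2)cc2cnc(Nc3ccc4[nH]ccc4c3)nc21` gives 600 nM. Compound 1 stands second highest of the three: its number and that of compound 3 lie within the scatter of each other, while compound 2 gives a number beyond the scatter above it.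

Compound 4 `Cn1c(=O)c(S(=O)(=O)c2ccc(O)cc2)cc2cnc(Nc3ccc4[nH]ccc4c3)nc21` has not yet been measured in this assay. Against compound 1 the change is 4-hydroxyphenyl in place of 2,4-dichlorophenyl on a sulfonyl sulfur. Going by the values given here, no measured pair shows this change on its own, so its size is open. The numbers of compound 1 and compound 3 show that two different groups on the sulfonyl sulfur sit within the scatter of each other, which gives no ground to expect a large step. The step from compound 1 to compound 4 is therefore estimated as a 1.7-fold lower number from compound 1 to compound 4 (0.22 log units; within the scatter), small and towards a lower number, not clearly beyond the scatter. Compound 4 is expected to give about 600 nM, with a range from 150 nM to 2500 nM.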

Compound 4, half-maximal inhibitory concentration: 100 nM
Estimate against measurement, compound 4: 6.0-fold (0.78 log units) above; measured number outside the range, below it.
By their numbers in this assay, from the lowest: compound 4; then compounds 3 and 1 (each within the scatter of the next); then compound 2.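

In this assay the group on the sulfonyl sulfur can move the number beyond the scatter: the series shows a 10-fold lower number from compound 1 to compound 4 (1.00 log units; beyond the scatter) with 4-hydroxyphenyl in place of 2,4-dichlorophenyl. Going by these compounds alone, the earlier compounds gave no single-place step at this position, and compound 1 and compound 3 lay within the scatter of each other, so this is the first sign that the position responds to change. No measurement at hand accounts for the size of this step.

This one change removes both chlorines and brings in the hydroxyl, so the compounds shown do not separate the two, and a plain phenyl or a 4-chlorophenyl would bear on that. Going by these compounds, whether a methoxy, an amine or a carboxylic acid in place of the hydroxyl keeps the lower number also stays open.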